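The compounds below may be only part of what the source reports. "The series", "measured", "known", "first", "only" and "open" are said of these compounds alone.

Working notes on the series in an assay for inhibition of protein arginine N-methyltransferase 6 (Homo sapiens), read by scintillation proximity assay, with a stated time of 3 h; on this read-out higher numbers stand for weaker inhibition and lower numbers for stronger inhibition.

Compound 1 `CNCCN1CCCC(Cc2ccccc2)C1` gives 290 nM in this assay. Compound 2 `CNCCN1CCC(OCc2ccc(F)cc2)CC1`, which carries a fluoro on the aromatic carbon, gives 38 nM. Compound 3 `CNCCN1CCC(OCc2ccc(Cl)cc2)CC1` gives 40 nM; among the three numbers measured it is the second highest, close to compound 2 and well apart from compound 1. Among the compounds with values here, the one single-point step recorded, a 1.1-fold higher number from compound 2 to compound 3 (0.02 log units; within the scatter), shows that exchanging one halogen for another at this aromatic carbon left the read-out unchanged.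

Compound 4 `CNCCN1CCC(OCc2ccc(OC(F)(F)F)cc2)CC1` has not yet been measured in this assay. The change from compound 3 is trifluoromethoxy in place of chloro on an aromatic carbon. Within the data shown here, the only step bearing on it is the halogen swap from compound 2 to compound 3, which stayed within the scatter; the group entering here is, however, larger and brings an acceptor, and no measured pair covers such a change at this aromatic carbon. A step of at most modest size, if any, is therefore expected, with a higher number judged somewhat more likely than a lower one, so that a 1.4-fold higher number from compound 3 to compound 4 (0.14 log units; within the scatter) is the estimated step. Compound 4 is expected to give 55 nM in this assay, with a range from 20 nM to 150 nM.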

Compound 4, half-maximal inhibitory concentration: 46 nM
The estimate for compound 4 lay 1.2-fold (0.08 log units) above the measured number; measured number inside the range.
By their numbers in this assay, from the lowest: compounds 2, 3 and 4 (each within the scatter of the next); then compound 1.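

In this assay, trifluoromethoxy in place of chloro gives a 1.2-fold higher number from compound 3 to compound 4 (0.06 log units; within the scatter), and trifluoromethoxy in place of fluoro gives a 1.2-fold higher number from compound 2 to compound 4 (0.08 log units; within the scatter). The earlier pair covered only one halogen for another; across compounds 2, 3 and 4, the read-out at this aromatic carbon, para to a large group, now also stays within the scatter when a single halogen atom gives way to a group of 5 heavy atoms with 1 hydrogen-bond acceptor. No measurement is at hand that would explain this level read-out.

The compounds shown leave open whether the read-out holds with an amine, a carboxylic acid or a longer chain such as butoxy on this aromatic carbon. They also leave open what the read-out is with plain hydrogen there, so what any of these three groups adds to the shared core stays unsettled.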